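Removing a trifluoromethyl group in the anilide series

The compounds below may be only part of what the source reports. "The series", "measured", "known", "first", "only" and "open" are said of these compounds alone.

Measured so far:
compound 1, `O=C(Nc1cc(C(F)(F)F)cc(C(F)(F)F)c1)c1cc(Cl)ccc1OCc1ccccc1` — > 100000 nM
compound 2, `O=C(Nc1ccc(C(F)(F)F)c(C(F)(F)F)c1)c1cc(Cl)ccc1O` — 13000 nM
compound 3, `O=C(Nc1ccc(Br)c(C(F)(F)F)c1)c1cc(Cl)ccc1O` — 30000 nM

In an assay for inhibition of transmembrane protease serine 4 (Homo sapiens), read by fluorescence (on this read-out higher numbers stand for weaker inhibition and lower numbers for stronger inhibition), compound 1 gives only a limit, > 100000 nM; this is the limit of > 100000 nM in this assay, at which 1 of the 3 values shown sits, and not a number. Compound 2 gives 13000 nM and holds the lowest of the two numbers. Among the measured compounds shown here, compound 3 gives 30000 nM, and the only single-point step measured, a 2.3-fold higher number from compound 2 to compound 3 (0.36 log units; beyond the scatter), is a modest weakening.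

Compound 4, `O=C(Nc1ccc(C(F)(F)F)cc1)c1cc(Cl)ccc1O`, is not yet measured. It differs from compound 2 by hydrogen in place of trifluoromethyl on an aromatic carbon. For the measured compounds named here, the one step that bears on this place is a 2.3-fold higher number from compound 2 to compound 3 (0.36 log units; beyond the scatter), where a bromo group stood in for the trifluoromethyl and the number rose modestly; taking the group away altogether leaves nothing in that place, so a step of at least that size, in the same direction, is expected in this assay. Compound 4 is therefore expected to give 40000 nM, within a range of 15000 nM to 100000 nM. This estimate for compound 4 means a step of a 3.1-fold higher number from compound 2 to compound 4 (0.49 log units; beyond the scatter). Because compound 1 sits at the limit of > 100000 nM in this assay, at which 1 of the 3 values shown sits, a limit rather than a number for compound 4 cannot be excluded.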

Compound 4, half-maximal inhibitory concentration: 16000 nM
Compound 4: middle estimate off by 2.5-fold (0.40 log units), on the high side; the measured number falls inside the stated range.
By their numbers in this assay, from the lowest: compounds 2, 4 and 3 (each within the scatter of the next, the first and the last beyond it). At a limit, above all of these: compound 1.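

In this assay, taking this trifluoromethyl group away, ortho to a trifluoromethyl group, gives a 1.2-fold higher number from compound 2 to compound 4 (0.09 log units; within the scatter) and so leaves no measurable difference at this place. The earlier step of a 2.3-fold higher number from compound 2 to compound 3 (0.36 log units; beyond the scatter) lies at the other trifluoromethyl group, which compound 4 keeps and compound 3 does not, and so it says nothing about this place; the two places now read differently, and only the other one has shown a step beyond the scatter. Nothing on hand accounts for this difference between the two places.

Open, from the compounds shown here alone, is whether a different group at this place, such as an amine, a carboxylic acid or a longer chain, would move the number in this assay in either direction. Also open, going by these compounds, is what hydrogen in place of the remaining trifluoromethyl group would give.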